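The source may report more compounds than this note shows. Statements on the series, on what has been measured and on what is new or still open speak of the compounds shown alone.

Measured compounds:
- Compound 1, `COc1ccc(/C=N/NC(=S)NC(C)(C)[C@H]2CC=C(C)CC2)cc1`: 12200 nM
- Compound 2, `CC1=CC[C@H](C(C)(C)NC(=S)N/N=C/c2ccc(F)cc2)CC1`: a limit, > 100000 nM
- Compound 3, `CC1=CC[C@H](C(C)(C)NC(=S)N/N=C/c2ccccc2Cl)CC1`: 74600 nM

In an ADME assay on Vero cells (Chlorocebus sabaeus) for inhibition, read by sulforhodamine B assay, with a stated time of 48 h (on this read-out higher numbers stand for weaker inhibition of growth and lower numbers for stronger inhibition of growth), compound 3 gives the highest number of the two that are numbers, with compound 1 nearest at a 6.1-fold higher number from compound 1 to compound 3 (0.79 log units; beyond the scatter). For compound 2 the value is only a limit of the assay. Compound 4, `CC1=CC[C@H](C(C)(C)NC(=S)N/N=C/c2ccc[nH]2)CC1`, differs from compound 3 by 1H-pyrrol-2-yl in place of 2-chlorophenyl on a carbon with a double bond to nitrogen. For the measured compounds named here, the steps that bear on this are the two earlier swaps of the aryl group on the same carbon: a 6.1-fold higher number from compound 1 to compound 3 (0.79 log units; beyond the scatter) and an at least 1.3-fold lower number from compound 2 to compound 3 (0.12 log units; that floor lies within the scatter), one modest and one within the scatter. A change of similar size, in either direction, is therefore expected, with no firm lean; the expected step is a 1.1-fold higher number from compound 3 to compound 4 (0.03 log units; within the scatter). Compound 4 is estimated at 80000 nM, from 25000 nM to 250000 nM.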

Compound 4, concentration for 50% growth inhibition: 20500 nM
Compound 4: middle estimate off by 3.9-fold (0.59 log units), on the high side; the whole stated range lies above it.
By their numbers in this assay, from the lowest: compounds 1 and 4 (each within the scatter of the next); then compound 3. At a limit, above all of these: compound 2.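

In this assay, a five-membered aromatic ring with one hetero atom now appears on this carbon, where only substituted phenyl groups stood before. 1H-pyrrol-2-yl gives stronger growth inhibition than 2-chlorophenyl (a 3.6-fold lower number from compound 3 to compound 4 (0.56 log units; beyond the scatter)) and cannot be told apart from 4-methoxyphenyl (a 1.7-fold higher number from compound 1 to compound 4 (0.23 log units; within the scatter)). The step from 4-fluorophenyl is only a floor (an at least 4.8-fold lower number from compound 2 to compound 4 (0.68 log units; beyond the scatter)), set by a limit: (the limit of > 100000 nM in this assay, at which 1 of the 4 values shown sits).

The compounds shown leave open whether the hydrogen on the ring nitrogen matters. A furan-2-yl or 1-methylpyrrol-2-yl group on this carbon would bear on that.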